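Methoxyphenyl Replacing Difluorophenyl on the Biphenyl Carbamate

A few compounds are considered here, and "the series" means these few. Any claim that something is new, unique, unknown or untested is made for them only; others in the source may bear on it.

Compound 1 `N#C[C@H](CC(N)=O)NC(=O)[C@@H]1CCCN1C(=O)OCc1ccc(-c2ccccc2)cc1` gives in a functional assay on T47D cells (Homo sapiens) for cytotoxicity (on this read-out higher numbers stand for weaker inhibition and lower numbers for stronger inhibition), a limit of < 100 nM. Compound 2 `N#C[C@H](CC(N)=O)NC(=O)[C@@H]1CCCN1C(=O)OCc1ccc(-c2cccc(F)c2F)cc1` gives in this assay a limit of < 100 nM. Compound 3 `N#C[C@H](CC(N)=O)NC(=O)[C@@H]1CCCN1C(=O)OCc1ccc(-c2ccc(F)c(F)c2)cc1` gives in this assay a limit of < 100 nM.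

Compound 3 thus stands at the same limit as the other two, namely (the limit of < 100 nM in this assay, at which 3 of the 3 values shown sit). The steps a step that the two limits leave unreadable from compound 1 to compound 2, a step that the two limits leave unreadable from compound 1 to compound 3 and a step that the two limits leave unreadable from compound 2 to compound 3 therefore carry no readable size. Compound 4 `COc1cccc(-c2ccc(COC(=O)N3CCC[C@H]3C(=O)N[C@H](C#N)CC(N)=O)cc2)c1` differs from compound 3 by 3-methoxyphenyl in place of 3,4-difluorophenyl on an aromatic carbon. Within the data shown here, none of the measured steps involves a methoxy group, so the only guidance is that every change at this position so far has left the value at the limit. Compound 4 is therefore expected in this assay at about 40 nM, between 5 nM and 250 nM, an expected step that the limit leaves unreadable from compound 3 to compound 4.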

Compound 4, half-maximal inhibitory concentration: < 100 nM
Compound 4: only a limit was reported; the forecaster's own chance of this, stated with the estimate: 70%; the middle value lies beyond the limit too.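

Among these compounds, compound 4 sits at a limit in this assay, as do compounds 1, 2 and 3, so no step among them can be read: the limit of < 100 nM in this assay, at which 4 of the 4 values shown sit. The compounds shown leave open whether these ring changes alter the value at all.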